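This account rests on a few compounds, and the source may have more. Where it says the series, first, only, none or still open, it means among the compounds named here.

Compound 1 `O=C(NCCC1CCN(Cc2ccccc2)CC1)c1coc2ccccc2c1=O` is one of two compounds measured in an assay on isolated protein for inhibition of Amine oxidase [flavin-containing] B (Homo sapiens), read by fluorescence and Amplex Red, with stated times of 15 min and 20 min (a higher number here means a weaker inhibitor, a lower number a stronger inhibitor), where compound 1 gives 35300 nM, the lowest of the two numbers shown. Its nearest neighbour, compound 2 `Cc1ccc2occ(C(=O)NCCC3CCN(Cc4ccccc4)CC3)c(=O)c2c1`, carries methyl in place of hydrogen on an aromatic carbon and in this assay compound 2 gives 52500 nM; the step of a 1.5-fold higher number from compound 1 to compound 2 (0.17 log units; within the scatter) lies within the scatter, so the two values cannot be ordered. Compound 3 `O=C(NCCC1CCN(Cc2ccccc2)CC1)c1coc2cc(Br)ccc2c1=O` has not yet been measured in this assay. It differs from compound 1 by bromo in place of hydrogen on an aromatic carbon. Among the measured compounds shown here, the only measured step that bears on this change is the one from compound 1 to compound 2, a substitution of a hydrogen on an aromatic carbon of the shared core, and that step stayed within the scatter. On that basis a step of about a 1.0-fold lower number from compound 1 to compound 3 (0.00 log units; within the scatter) is expected for compound 3, with no direction beyond the scatter, and compound 3 is estimated at 35000 nM in this assay, between 12000 nM and 100000 nM.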

Compound 3, half-maximal inhibitory concentration: 29500 nM
Estimate against measurement, compound 3: 1.2-fold (0.07 log units) above; low and high end bracket the measured number.
By their numbers in this assay, from the lowest: compounds 3, 1 and 2 (each within the scatter of the next).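

In this assay, among the compounds shown here, bromo in place of hydrogen on an aromatic carbon gives a 1.2-fold lower number from compound 1 to compound 3 (0.08 log units; within the scatter), so a bromine atom at this place, meta to a fused ring and para to a fused ring, produces no step that can be told from the scatter. Alongside a 1.5-fold higher number from compound 1 to compound 2 (0.17 log units; within the scatter), this is a second substitution of a hydrogen on an aromatic carbon of the shared core that stays within the scatter. Nothing measured alongside these numbers speaks to the reason for this result.

The compounds shown leave open whether a different group at this place, such as an amine or a carboxylic acid, would move the number beyond the scatter. They also leave open whether a change away from the aromatic ring, such as a longer chain between the amide and the rest of the molecule, would do so.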